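The source may hold more compounds than are shown below. What is called first, only, known or untested is meant among the compounds shown, and "the series" means these compounds.

Measured so far in a functional assay on MCF7 cells (Homo sapiens) for antiproliferative activity, read by MTT assay; on this read-out higher numbers stand for weaker inhibition and lower numbers for stronger inhibition:
- compound 1 `COc1ccc([C@@H]2C(c3ccoc3)C(=O)N2c2cc(OC)c(OC)c(OC)c2)cc1` gives 150 nM
- compound 2 `COc1ccc([C@@H]2[C@@H](c3cccs3)C(=O)N2c2cc(OC)c(OC)c(OC)c2)cc1N` gives 42 nM

Of the two numbers in this assay, compound 1 has the highest; the nearest is compound 2, whose number is lower by a gap that lies beyond the scatter. Among the measured compounds shown here, compound 2 differs from compound 1 in more than one place, so no single step between them is defined.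

The unmeasured compound 3 `COc1ccc([C@@H]2C(c3ccsc3)C(=O)N2c2cc(OC)c(OC)c(OC)c2)cc1` keeps the shared core of compound 1 and changes one group: thiophen-3-yl in place of furan-3-yl on a saturated ring carbon. A heteroatom swap of this kind on a saturated ring carbon leaves size and hydrogen-bond count unchanged, and nothing in the two measured compounds isolates its effect. The step in this assay is therefore expected to be small, likely within the scatter, with no clear direction.

Compound 3 is expected to give 120 nM, within 50 nM to 300 nM, the expected step being a 1.3-fold lower number from compound 1 to compound 3 (0.10 log units; within the scatter).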

Compound 3, half-maximal inhibitory concentration: 60 nM
Compound 3: the middle estimate sits 2.0-fold (0.30 log units) above what was measured; the range from low to high includes it.
By their numbers in this assay, from the lowest: compounds 2 and 3 (each within the scatter of the next); then compound 1.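

In this assay, the saturated ring carbon of the four-membered ring responds to a change of the five-membered aromatic ring it carries: thiophen-3-yl in place of furan-3-yl gives a 2.5-fold lower number from compound 1 to compound 3 (0.40 log units; beyond the scatter), a modest step. The earlier compounds shown here did not isolate this position; this pair shows that sulfur in place of oxygen moves the number, with the heavy-atom and hydrogen-bond counts unchanged. No measurement at hand bears on the origin of this step.

The compounds shown leave open how this position takes a phenyl group, a pyridin-3-yl group or an aminomethyl group. They also leave open whether the same step holds in the presence of the amino group of compound 2.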